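Aryl sulfanyl for aryl ether on a shared quinoxaline-type core

The source may hold more compounds than are shown below. What is called first, only, known or untested is meant among the compounds shown, and "the series" means these compounds.

Compound 1 `Nc1cc(N)c2nc(-c3ccccc3)c(Oc3ccc(Cl)c(Cl)c3)nc2c1` — < 100000 nM
Compound 2 `Nc1cc(N)c2nc(-c3ccccc3)c(NCc3ccc(Cl)c(Cl)c3)nc2c1` — 75900 nM
Compound 3 `CCOC(=O)[C@H](CCC(=O)O)NC(=O)c1ccc(Sc2nc3cc(N)cc(N)c3nc2-c2ccccc2)cc1` — < 100000 nM

The three measured compounds share one core and differ in the group on the aromatic carbon next to the ring nitrogen. In a functional assay on M14 cells (Homo sapiens) for inhibition, read by sulforhodamine B assay, with a stated time of 48 h (a higher number here means that more compound is tolerated, a lower number that less compound is tolerated), compound 1 gives < 100000 nM, which is a limit of the assay and not a number. Compound 3 likewise gives only a limit, < 100000 nM. Among the measured compounds shown here, compound 2 is the one member with a number, at 75900 nM. For the measured compounds named here, compound 1 therefore stands with the majority of the set at the limit (the limit of < 100000 nM in this assay, at which 2 of the 3 values shown sit), and no measured step is available for it.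

Compound 4 `Nc1cc(N)c2nc(-c3ccccc3)c(Sc3ccc(F)cc3)nc2c1` has not been measured. It differs from compound 1 in one place: (4-fluorophenyl)sulfanyl in place of 3,4-dichlorophenoxy on an aromatic carbon. Without a measured step to lean on, the author expects no movement beyond the usual scatter in this assay, with a real chance that the assay again reports only a limit. The estimate for compound 4 is 70000 nM, between 30000 nM and 100000 nM, which is expected to mean a step that the limit leaves unreadable from compound 1 to compound 4.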

Compound 4, concentration lethal to 50% of the cells: 58900 nM
Compound 4: the middle estimate sits 1.2-fold (0.07 log units) above what was measured, within the range that was stated.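

No step can be read between compound 1 and compound 4, because compound 1 is reported only as a limit of the assay: the limit of < 100000 nM in this assay, at which 2 of the 4 values shown sit.

The compounds shown leave open whether (4-fluorophenyl)sulfanyl in place of 3,4-dichlorophenoxy shifts the lethal concentration at all in this assay.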